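Ester for Amide: Tolerance of Silyl-Protected Nucleoside Analogues

The source may report more compounds than this note shows. Statements on the series, on what has been measured and on what is new or still open speak of the compounds shown alone.

Four close relatives of one protected nucleoside are compared here for how much of each a human cell line tolerates, measured in a functional assay on HEL cells (Homo sapiens) for cytotoxicity, read by microscopy; a higher number here means that more compound is tolerated, a lower number that less compound is tolerated. Compound 1, `Cc1cn([C@@H]2O[C@H](CO[Si](C)(C)C(C)(C)C)[C@@]3(OS(=O)(=O)C=C3NCC(N)=O)[C@H]2O[Si](C)(C)C(C)(C)C)c(=O)n(C)c1=O`, gives 16000 nM in this assay. Compound 2, `COC(=O)CNC1=CS(=O)(=O)O[C@@]12[C@@H](CO[Si](C)(C)C(C)(C)C)O[C@@H](n1cc(C)c(=O)n(C)c1=O)[C@@H]2O[Si](C)(C)C(C)(C)C`, is reported only as >= 400000 nM, which is a limit of the assay and not a number. Compound 3, `Cc1cn([C@@H]2O[C@H](CO[Si](C)(C)C(C)(C)C)[C@@]3(OS(=O)(=O)C=C3NCCC(N)=O)[C@H]2O[Si](C)(C)C(C)(C)C)c(=O)n(C)c1=O`, likewise reaches only >= 80000 nM, again a limit rather than a number.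

The first and second compounds differ in one place: methoxy in place of amino on a carbonyl carbon. That change produced an at least 25-fold higher number from compound 1 to compound 2 (1.39 log units; beyond the scatter). The cores of compound 1 and compound 3 differ as follows: carbamoylmethyl in place of carbamoyl on a saturated chain carbon bound to an amine nitrogen. That lengthening gave an at least 5.0-fold higher number from compound 1 to compound 3 (0.69 log units; beyond the scatter). Between compound 2 and compound 3 the two limits leave the step unreadable: a step that the two limits leave unreadable from compound 2 to compound 3.

Compound 4, `COC(=O)CCNC1=CS(=O)(=O)O[C@@]12[C@@H](CO[Si](C)(C)C(C)(C)C)O[C@@H](n1cc(C)c(=O)n(C)c1=O)[C@@H]2O[Si](C)(C)C(C)(C)C`, has not yet been measured in this assay. Among the compounds with values here, it differs from compound 3 by methoxy in place of amino on a carbonyl carbon, the same change, at the same kind of place, as the one that separates compound 1 from compound 2. Because the earlier instance gave an at least 25-fold higher number from compound 1 to compound 2 (1.39 log units; beyond the scatter), the step from compound 3 to compound 4 is expected to be of similar direction, a step that the limit leaves unreadable from compound 3 to compound 4, though compound 3 already sits at a limit so the size is uncertain. Compound 4 is therefore estimated at 400000 nM, between 100000 nM and 1000000 nM, most probably reported as a limit again.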

Compound 4, minimum cytotoxic concentration: >= 400000 nM
Compound 4: no number, only a limit; the forecaster's own chance of this, stated with the estimate: 80%; the middle value lies on the limit itself.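

In this assay compound 4 gives >= 400000 nM, which is a limit of the assay and not a number. Compound 3 gives >= 80000 nM, also a limit and not a number, so no size can be read for any step among compound 2, compound 3 and compound 4, including the direct test of methoxy in place of amino on the longer chain. Within the data shown here, the one new step that can be read is an at least 25-fold higher number from compound 1 to compound 4 (1.39 log units; beyond the scatter), which points the same way as an at least 25-fold higher number from compound 1 to compound 2 (1.39 log units; beyond the scatter), but it swaps the amide for the ester and lengthens the chain at once, so it shows only that nothing here goes against the direction seen on the shorter chain, not that the size of the effect carries over.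

The compounds shown leave open how far the true values of compound 2, compound 3 and compound 4 lie beyond their limits, and so whether the ester adds anything on the longer chain. Also open, from the compounds shown here alone, is what a carboxylic acid, or a still longer chain ending in the amide or the ester, would give in this assay.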